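Amide replacement on the chlorobenzoxazole thioether series

The source may report more compounds than this note shows. Statements on the series, on what has been measured and on what is new or still open speak of the compounds shown alone.

Compound 1 `O=C(CCSc1nc2cc(Cl)ccc2o1)N1CCS(=O)(=O)C1` sits lowest of the three compounds measured in an ADME assay on microsomes from liver (Mus musculus) for metabolic stability, read by LC-MS, using NADPH, with a stated time of 45 min, tested at 0.5 uM (on this read-out higher numbers stand for fast clearance and lower numbers for slow clearance), giving 8.9 mL/min/g. Compound 2 `O=C(CCCc1nc2cc(Cl)ccc2o1)N1CCCC1`, which carries a pyrrolidine amide on a three-carbon chain, gives 115 mL/min/g in this assay, and compound 3 `O=C(CCSc1ncc(-c2ccccc2)o1)N1CCCC1`, also a pyrrolidine amide on a thioether linker with a different core, gives 177 mL/min/g; both of these numbers lie well beyond the scatter above compound 1.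

Compound 4 `CN(C)C(=O)CCSc1nc2cc(Cl)ccc2o1` differs from compound 1 only at the amide: dimethylamino in place of 1,1-dioxo-1,3-thiazolidin-3-yl on a carbonyl carbon. Among the measured compounds shown here, no measured pair in the set isolates this change, so its size is not known from direct comparison. For the measured compounds named here, the only guide is that both compounds built on a different amide nitrogen, compound 2 and compound 3, sit at markedly higher clearance than compound 1. The step from compound 1 to compound 4 is therefore expected to be an increase, a 4.5-fold higher number from compound 1 to compound 4 (0.65 log units; beyond the scatter), larger than the scatter but uncertain in size. Compound 4 is estimated at 40 mL/min/g, with a range of 12 mL/min/g to 130 mL/min/g.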

Compound 4, intrinsic clearance in a liver preparation (reported as CLH), per the amount of preparation that the assay uses: 41.8 mL/min/g
For compound 4 the middle estimate is 1.0-fold (0.02 log units) below the measured one; measured number inside the range.
By their numbers in this assay, from the lowest: compound 1; then compound 4; then compounds 2 and 3 (each within the scatter of the next).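

Among the compounds shown here, exchanging the 1,1-dioxo-1,3-thiazolidin-3-yl group for dimethylamino on a carbonyl carbon gives the first direct reading at this position in this assay (a 4.7-fold higher number from compound 1 to compound 4 (0.67 log units; beyond the scatter)). With the core and thioether chain unchanged, the amide group alone moves the read-out beyond the scatter, which compound 2 and compound 3 could not show, as each differs from compound 1 in more than one place. Nothing available here accounts for the size of this step.

Still open, on these data alone, is which part of the 1,1-dioxo-1,3-thiazolidin-3-yl group goes with the lower number, since a single exchange removes the ring and its oxygens together. A 1,3-thiazolidin-3-yl amide without the two oxygens and a morpholine amide, each on the same core and chain, would separate these parts.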